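Swapping the aniline ring on a quinoxaline sulfone core

This account rests on a few compounds, and the source may have more. Where it says the series, first, only, none or still open, it means among the compounds named here.

Three compounds share one core, a quinoxaline that carries an aryl sulfone on one carbon and an arylamine on the neighbouring carbon. Compound 1 `COc1cc(Nc2nc3ccccc3nc2S(=O)(=O)c2ccc(C)cc2)cc(OC)c1` gives 8060 nM in a functional assay on A549 cells (Homo sapiens) for cytotoxicity, read by MTT assay, with a stated time of 72 h; a lower number here means a stronger inhibitor, a higher number a weaker inhibitor. Compound 2 `Cc1ccc(S(=O)(=O)c2nc3ccccc3nc2Nc2ccc(N)cc2)cc1` gives 24600 nM in this assay, and compound 3 `COc1ccc(S(=O)(=O)c2nc3ccccc3nc2Nc2cc(OC)cc(OC)c2)cc1` gives 12700 nM in this assay.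

Compound 2 differs from compound 1 by 4-aminophenyl in place of 3,5-dimethoxyphenyl on a nitrogen on an aromatic ring, and that change made a 3.1-fold higher number from compound 1 to compound 2 (0.48 log units; beyond the scatter). Compound 3 differs from compound 1 only in its core, by methoxy in place of methyl on an aromatic carbon, a step of a 1.6-fold higher number from compound 1 to compound 3 (0.20 log units; within the scatter).

Compound 4 `COc1ccc(S(=O)(=O)c2nc3ccccc3nc2Nc2ccc(N)cc2)cc1` has not been measured yet. It differs from compound 3 by 4-aminophenyl in place of 3,5-dimethoxyphenyl on a nitrogen on an aromatic ring, the same change, in the same place, as that from compound 1 to compound 2. The step is expected to be about a 3.1-fold higher number from compound 3 to compound 4 (0.49 log units; beyond the scatter) in this assay, because the same change gave a 3.1-fold higher number from compound 1 to compound 2 (0.48 log units; beyond the scatter) on the closely related core. On that basis compound 4 is expected to give around 39000 nM in this assay, most likely between 15000 nM and 100000 nM.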

Compound 4, half-maximal inhibitory concentration: 2990 nM
The estimate for compound 4 lay 13-fold (1.12 log units) above the measured number, and the stated range ends above it.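

In this assay, the swap to 4-aminophenyl from 3,5-dimethoxyphenyl did not carry over from one core to the other: here it gave a 4.2-fold lower number from compound 3 to compound 4 (0.63 log units; beyond the scatter), opposite in direction to the earlier step, as the comparison shows: the same change on two cores in this assay, a 3.1-fold higher number (0.48 log units; beyond the scatter) from compound 1 to compound 2 and a 4.2-fold lower number (0.63 log units; beyond the scatter) from compound 3 to compound 4, 13-fold (1.11 log units) apart, beyond the scatter of two such steps. The change to methoxy from methyl on an aromatic carbon also depended on the group on the nitrogen, giving an 8.2-fold lower number from compound 2 to compound 4 (0.92 log units; beyond the scatter), which compares with its earlier step as follows: the same change on two cores in this assay, a 1.6-fold higher number (0.20 log units; within the scatter) from compound 1 to compound 3 and an 8.2-fold lower number (0.92 log units; beyond the scatter) from compound 2 to compound 4, 13-fold (1.11 log units) apart, beyond the scatter of two such steps. The two changes therefore do not act independently across these four compounds, but this does not show why they interact, or that the same would hold elsewhere in the series.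

From the compounds shown here alone, it remains open whether the reversal belongs to 4-aminophenyl itself or would also appear with another group on that nitrogen, such as a hydroxyphenyl or an unsubstituted phenyl. A chlorine in place of the methoxy or methyl could show whether the gain seen with compound 4 needs methoxy specifically.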